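One Fluoro on a Weak Growth Inhibitor

A few compounds are considered here, and "the series" means these few. Any claim that something is new, unique, unknown or untested is made for them only; others in the source may bear on it.

In a functional assay on DWD cells (Homo sapiens) for inhibition, read by sulforhodamine B assay (on this read-out higher numbers stand for weaker inhibition of growth and lower numbers for stronger inhibition of growth), compound 1 `c1ccc(-c2ccc(-c3ccc(-c4nc5ccccc5[nH]4)cc3)cc2)cc1` gives 100000 nM as the highest of three measured numbers. Compound 2 `Cc1ccc2[nH]c(-c3ccc(-c4ccc(-c5ccc(N(C)C)cc5)cc4)cc3)nc2c1` reads 3230 nM and compound 3 `COc1cc(-c2ccc(-c3ccc(-c4nc5cc(C)ccc5[nH]4)cc3)cc2)cc(OC)c1OC` reads 170 nM in this assay as well. Both lie beyond the scatter from compound 1, so compound 1 stands at the weak end of this small set. Both also differ from compound 1 in more than one place, and neither shows what a single change does on its own.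

Compound 4 `Fc1ccc(-c2ccc(-c3ccc(-c4nc5ccccc5[nH]4)cc3)cc2)cc1` has not yet been measured. It keeps the core of compound 1 and changes one place only: fluoro in place of hydrogen on an aromatic carbon describes the step, fluoro in place of hydrogen on an aromatic carbon, which turns phenyl to 4-fluorophenyl.

Compound 2 at 3230 nM and compound 3 at 170 nM show that relatives of compound 1 carrying added groups can reach much lower numbers, but fluoro adds far less than they do. The expected change is a modest fall in the number, estimated as a 3.3-fold lower number from compound 1 to compound 4 (0.52 log units; beyond the scatter) in the direction of stronger inhibition of growth, and it may stay within the scatter. For compound 4 the estimate is 30000 nM with an expected range from 6000 nM to 100000 nM in this assay when measured.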

Compound 4, concentration for 50% growth inhibition: 35600 nM
Compound 4: the middle estimate sits 1.2-fold (0.07 log units) below what was measured; measured number inside the range.
By their numbers in this assay, from the lowest: compound 3; then compound 2; then compound 4; then compound 1.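

Within the data shown here, changing phenyl to 4-fluorophenyl gives a 2.8-fold lower number from compound 1 to compound 4 (0.45 log units; beyond the scatter) in this assay, and this is the only step here in which a single change can be read on its own. It shows that this place, on an aromatic carbon para to a large group, responds to a swap as small as one hydrogen for one fluorine, with a modest move toward stronger inhibition of growth. The compounds offer no separate measurement that could explain this move.

Among these compounds, whether a chloro, a nitrile or a carboxylic acid on the same carbon would move the number further, less far or the opposite way remains open, since fluoro is the only group whose effect at this place can be read. As far as these compounds go, compound 2 and compound 3 differ from compound 1 in more than one place, so their lower numbers cannot be divided among their separate changes, and the part played by each added group on its own remains unknown.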